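The source may report more compounds than this note shows. Statements on the series, on what has been measured and on what is new or still open speak of the compounds shown alone.

Measured so far in a functional assay with Oryctolagus cuniculus as the target; a lower number here means a stronger inhibitor, a higher number a weaker inhibitor:

- compound 1 `COc1ccc(-c2nc(CN(C)C)sc2-c2ccc(OC)cc2)cc1`: 96 nM
- compound 2 `COc1ccc(-c2nc(C(=O)N(C)C)sc2-c2ccc(OC)cc2)cc1`: < 100 nM

Compound 2 stands at < 100 nM, and this is a limit of the assay, not a number. Its exact place is therefore unknown.

Compound 3 `CCN(CC)C(=O)c1nc(-c2ccc(OC)cc2)c(-c2ccc(OC)cc2)s1` keeps the core of compound 2 and has diethylamino in place of dimethylamino on a carbonyl carbon.

Among the compounds with values here, only one measured step exists, a step that the limit leaves unreadable from compound 1 to compound 2. It concerns a different change and has no readable size, so it offers no guide to this one. Within the data shown here, with no measured step to suggest a shift, the expected change is none beyond the usual scatter, and the range must stay wide. The expected step is a step that the limit leaves unreadable from compound 2 to compound 3. The estimate for compound 3 is 80 nM, with an expected range from 15 nM to 400 nM.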

Compound 3, half-maximal inhibitory concentration: < 10 nM
Compound 3: no number, only a limit (the forecaster's own chance of this, stated with the estimate: 30%); at least 8.0-fold (0.90 log units) between middle value and limit.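

In this assay compound 3 gives < 10 nM, which is a limit of the assay and not a number. Even so, one step can be read: the change on an aromatic carbon gives an at least 9.6-fold lower number from compound 1 to compound 3 (0.98 log units; beyond the scatter), so this position can hold a group that clearly lowers the number. The steps that involve compound 2 cannot be read, because its value is also a limit: the limit of < 100 nM in this assay, at which 1 of the 3 values shown sits.

As far as these compounds go, whether diethylamino in place of dimethylamino on a carbonyl carbon changes the number at all therefore stays open, and so does the true value of compound 3. From the compounds shown here alone, it is also open whether a longer chain, such as dipropylamino on a carbonyl carbon, would keep the number this low.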